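The source may report more compounds than this note shows. Statements on the series, on what has been measured and on what is new or still open speak of the compounds shown alone.

Compound 1, `ClCc1ccccc1Cn1cnc2c(Cl)nc(Cl)nc21`, gives 3630 nM.
Compound 2, `ClCc1ccccc1Cn1cnc2c(Cl)ncnc21`, gives 6020 nM.
Compound 3, `ClCc1ccccc1Cn1cnc2ncnc(Cl)c21`, gives 28800 nM.

These three compounds were compared in a functional assay on HOP-62 cells (Homo sapiens) for cytotoxicity, read by sulforhodamine B assay, with a stated time of 48 h; a lower number here means a stronger inhibitor of growth, a higher number a weaker inhibitor of growth. Compound 1 and compound 2 share one core and differ only by chloro in place of hydrogen on an aromatic carbon; the move from the hydrogen-bearing compound 2 to the chloro-bearing compound 1 gave a 1.7-fold lower number from compound 2 to compound 1 (0.22 log units; within the scatter), so the two are not separated by the measurements. Compound 3 carries the same atoms as compound 2 joined differently; the difference between the two cores is not broken down here. Compound 3 stands highest of the three in this assay, and its gap to compound 2 and to compound 1 lies beyond the scatter.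

Compound 4, `ClCc1ccccc1Cn1cnc2nc(Cl)nc(Cl)c21`, has not been measured in this assay. It differs from compound 3 by chloro in place of hydrogen on an aromatic carbon, and the place is described in the same words as the change from compound 2 to compound 1, so it is the same change placed on the core of compound 3. For the measured compounds named here, compound 3 is the only anchor for compound 4, and the change is expected to give a step of about a 1.7-fold lower number from compound 3 to compound 4 (0.23 log units; within the scatter), the size resting on the step of a 1.7-fold lower number from compound 2 to compound 1 (0.22 log units; within the scatter) observed on the other core. Going by the values given here, compound 4 is therefore estimated at 17000 nM, with a range from 7000 nM to 40000 nM, the width reflecting that a single step on a different core is the only guide.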

Compound 4, concentration for total growth inhibition: 5490 nM
The estimate for compound 4 lay 3.1-fold (0.49 log units) above the measured number, and the stated range ends above it.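

In this assay, chloro in place of hydrogen on the aromatic carbon between two ring nitrogen atoms gave a 5.2-fold lower number from compound 3 to compound 4 (0.72 log units; beyond the scatter), so on the core of compound 3 this change separates the two compounds clearly. The same change did not carry over at the same size from one core to the other: the same change on two cores in this assay, a 1.7-fold lower number (0.22 log units; within the scatter) from compound 2 to compound 1 and a 5.2-fold lower number (0.72 log units; beyond the scatter) from compound 3 to compound 4, 3.2-fold (0.50 log units) apart, beyond the scatter of two such steps The number fell on both cores, but the step on the core of compound 1 cannot be told apart from repeat scatter, so the data show that the size of this step was not transferable between these two cores, yet they do not show what sets the size, and two cores give no rule for predicting the step on a third.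

The compounds shown carry only chloro or hydrogen at the changed carbon, so how an amine, a methoxy group or a bromo group at that carbon would compare with chloro remains open. Also open, going by these compounds, is whether a replacement such as an amine would show the same gap between the two cores, or whether that gap belongs to the chloro group alone.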